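The source may hold more compounds than are shown below. What is called first, only, known or untested is meant among the compounds shown, and "the series" means these compounds.

Measured so far:
compound 1, `COC(=O)c1c(Nc2ccc(OC)cc2)sc(C(=O)c2ccc(OC)cc2)c1C`, 7.8%
compound 2, `COC(=O)c1c(Nc2ccc(F)cc2)sc(C(=O)c2ccc(OC)cc2)c1C`, 15.2%
compound 3, `COc1ccc(Nc2sc(C(=O)c3ccc(OC)cc3)c(C)c2C(=O)O)cc1`, 30.6%

All three were tested in a functional assay, with a stated time of 150 min, tested at 15 ug/mL; a lower number here means a weaker effect, a higher number a stronger effect of the compound at the concentration tested. Compound 2 differs from compound 1 by fluoro in place of methoxy on an aromatic carbon, and the step of a number 7.4 percentage points higher from compound 1 to compound 2 (within the scatter) is small. Compound 3 differs from compound 1 by hydrogen in place of methyl on an oxygen next to a carbonyl group, and the step of a number 22.8 percentage points higher from compound 1 to compound 3 (beyond the scatter) is the larger of the two. Compound 3 thus gives the highest of the three numbers, with both of its steps to the others beyond the scatter.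

Compound 4, `COc1ccc(C(=O)c2sc(Nc3ccc(F)cc3)c(C(=O)O)c2C)cc1`, has not yet been measured in this assay. Among the measured compounds shown here, it differs from compound 3 by fluoro in place of methoxy on an aromatic carbon, which is the same change as the one from compound 1 to compound 2, made here on the core of compound 3; the two cores differ by hydrogen in place of methyl on an oxygen next to a carbonyl group. The place of the change reads the same in both cases, so it is the same change, occurring twice among these compounds. Because the earlier step of a number 7.4 percentage points higher from compound 1 to compound 2 (within the scatter) stayed within the scatter, the step from compound 3 to compound 4 is expected to be of a similar small size, a number 7.4 percentage points higher from compound 3 to compound 4 (within the scatter). For compound 4 the estimated value in this assay is 38%, with a range from 22% to 54%.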

Compound 4, a percentage reported as activity, at one concentration (the size of the read-out at that concentration, not a potency): 1.98%
The estimate for compound 4 lay 36 percentage points above the measured number, and the stated range ends above it.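

In this assay, fluoro in place of methoxy on the core of compound 3 gives a number 28.6 percentage points lower from compound 3 to compound 4 (beyond the scatter), so this step does not carry over from the core of compound 1: the same change on two cores in this assay, a number 7.4 percentage points higher (within the scatter) from compound 1 to compound 2 and a number 28.6 percentage points lower (beyond the scatter) from compound 3 to compound 4, 36 percentage points apart, beyond the scatter of two such steps

The other change, hydrogen in place of methyl, gives a number 13.2 percentage points lower from compound 2 to compound 4 (beyond the scatter), and its step also differs between the two cores: the same change on two cores in this assay, a number 22.8 percentage points higher (beyond the scatter) from compound 1 to compound 3 and a number 13.2 percentage points lower (beyond the scatter) from compound 2 to compound 4, 36 percentage points apart, beyond the scatter of two such steps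

Within these four compounds, the effect of each change therefore depends on the other change present, but this does not explain why, and with only two pairs for each change it gives no rule for other cores.

As far as these compounds go, it remains open how other groups on the same aromatic carbon, such as chloro, methyl or an amine, would behave on either core, and whether an amide in place of the carboxylic acid would follow compound 3 or compound 4. Each compound is also shown at only one concentration, so whether its effect would be stronger or weaker at other concentrations remains open.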